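This account rests on a few compounds, and the source may have more. Where it says the series, first, only, none or still open, it means among the compounds named here.

Compound 1, `CS(=O)(=O)c1ccc(Cc2nnc3n2N=C(c2ccccc2)CS3)cc1`: 55.5%
Compound 2, `CS(=O)(=O)c1ccc(Cc2nnc3n2N=C(c2cc(Cl)sc2S(N)(=O)=O)CS3)cc1`: 35.2%

In a functional assay on HT-29 cells (Homo sapiens) for cytotoxicity, read by MTT assay, with a stated time of 48 h, tested at 100 uM (on this read-out higher numbers stand for a stronger effect at the one concentration tested and lower numbers for a weaker effect), compound 2 gives 35.2%, the lower of the two numbers, below compound 1. Within the data shown here, the only measured step, a number 20.3 percentage points lower from compound 1 to compound 2 (beyond the scatter), exchanged the whole phenyl for the substituted thiophene and is modest. Compound 3, `CS(=O)(=O)c1ccc(Cc2nnc3n2N=C(c2cc(Cl)sc2Cl)CS3)cc1`, differs from compound 2 by chloro in place of sulfamoyl on an aromatic carbon. Among the measured compounds shown here, no measured step removes a sulfamoyl while the thiophene stays, so this change has no direct precedent. The step of a number 8.8 percentage points higher from compound 2 to compound 3 (within the scatter) is expected to be small and upward, close to the scatter. Compound 3 is estimated at 44%, between 26% and 62%.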

Compound 3, a percentage reported as activity, at one concentration (the size of the read-out at that concentration, not a potency): 47.3%
Compound 3: the middle estimate sits 3.3 percentage points below what was measured; low and high end bracket the measured number.
By their numbers in this assay, from the lowest: compound 2; then compounds 3 and 1 (each within the scatter of the next).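

In this assay, the step of a number 12.1 percentage points higher from compound 2 to compound 3 (beyond the scatter) shows that the effect responds to the group on this aromatic carbon next to the ring sulfur, when chloro replaces sulfamoyl. The step of a number 8.2 percentage points lower from compound 1 to compound 3 (within the scatter) stays within the scatter, so the 2,5-dichlorothiophen-3-yl group cannot be told apart from phenyl on this read-out. Nothing available explains either step.

Going by these compounds, whether an amine or a carboxylic acid at this place would read like chloro or like sulfamoyl remains open. So does whether these differences would hold at other concentrations, since a single concentration gives no potency.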